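Ethoxy for Ethyl on the Phenyl of Compound 3

The source may hold more compounds than are shown below. What is called first, only, known or untested is meant among the compounds shown, and "the series" means these compounds.

Measured compounds:
compound 1 `N#CC1=C(N)Oc2c(c3nc4ccccc4nc3c3ccccc23)C12C(=O)N(Cc1cnnn1-c1ccccc1Br)c1ccccc12` — > 50000 nM
compound 2 `N#CC1=C(N)Oc2c(c3nc4ccccc4nc3c3ccccc23)C12C(=O)N(Cc1cnnn1-c1ccc(F)c(Cl)c1)c1ccccc12` — > 50000 nM
compound 3 `CCc1ccccc1-n1nncc1CN1C(=O)C2(C(C#N)=C(N)Oc3c(N)cc4nc5ccccc5nc4c32)c2ccccc21` — 10300 nM

Of the compounds shown here, three from this series have been measured in a functional assay on HCT-116 cells (Homo sapiens) for antiproliferative activity, read by MTT assay, with a stated time of 48 h; on this read-out lower numbers stand for stronger inhibition and higher numbers for weaker inhibition. Compound 1 `N#CC1=C(N)Oc2c(c3nc4ccccc4nc3c3ccccc23)C12C(=O)N(Cc1cnnn1-c1ccccc1Br)c1ccccc12` reaches only a limit of the assay, > 50000 nM. Compound 2 `N#CC1=C(N)Oc2c(c3nc4ccccc4nc3c3ccccc23)C12C(=O)N(Cc1cnnn1-c1ccc(F)c(Cl)c1)c1ccccc12` likewise stops at a limit, > 50000 nM. The step that the two limits leave unreadable from compound 1 to compound 2 therefore cannot be read, as the limit of > 50000 nM in this assay, at which 2 of the 3 values shown sit, shows. Within the data shown here, compound 3 `CCc1ccccc1-n1nncc1CN1C(=O)C2(C(C#N)=C(N)Oc3c(N)cc4nc5ccccc5nc4c32)c2ccccc21` is the one compound with a number: in this assay compound 3 gives 10300 nM.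

Compound 4 `CCOc1ccccc1-n1nncc1CN1C(=O)C2(C(C#N)=C(N)Oc3c(N)cc4nc5ccccc5nc4c32)c2ccccc21` has not yet been measured. It differs from compound 3 in a single place, (ethoxy in place of ethyl on an aromatic carbon). Among the measured compounds shown here, no measured step touches this part of the molecule, and the one step that was measured, from compound 1 to compound 2, is unreadable between two limits. There is thus no measured evidence from which to expect a shift in either direction in this assay beyond the usual scatter.

Compound 4 is therefore expected to land close to compound 3, with the step of a 1.0-fold lower number from compound 3 to compound 4 (0.01 log units; within the scatter) estimated as no more than the scatter. The estimate for compound 4 is 10000 nM, with a range from 3500 nM to 35000 nM.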

Compound 4, half-maximal inhibitory concentration: > 50000 nM
Compound 4 ended at the assay's limit; the forecaster's own chance of this, stated with the estimate: 20%; middle value at least 5.0-fold (0.69 log units) from the limit.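

Among these compounds, the change from 2-ethylphenyl to 2-ethoxyphenyl gives the first readable step: in this assay, it is an at least 4.8-fold higher number from compound 3 to compound 4 (0.68 log units; beyond the scatter). This shows that the aromatic carbon ortho to a large group is not indifferent to what it carries, as the swap of ethyl for ethoxy, which brings in one oxygen and one hydrogen-bond acceptor, is enough to weaken inhibition beyond the scatter. Only the lower end of this step can be read, and nothing shown separates the part played by the oxygen from that of the group as a whole, since compound 4 stops at a limit of the assay: the limit of > 50000 nM in this assay, at which 3 of the 4 values shown sit.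

The compounds shown leave open whether a methyl, a hydroxyl or an amine on this carbon would keep the activity of compound 3, at 10300 nM, or lose it as the ethoxy group does. They also leave open whether a 2-ethylphenyl group would bring any measurable activity to the core of compound 1, which carries a 2-bromophenyl group instead.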